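Compound 3 and the loss of its fluoro

The source may report more compounds than this note shows. Statements on the series, on what has been measured and on what is new or still open speak of the compounds shown alone.

In a functional assay on HepG2 cells (Homo sapiens) for antiproliferative activity, read by MTT assay, with a stated time of 72 h (a lower number here means a stronger inhibitor, a higher number a weaker inhibitor), compound 1 `O=C(N/N=C/c1cccc([N+](=O)[O-])c1)Nc1ccc(Oc2ccnc3[nH]ccc23)c(F)c1` gives 5180 nM, compound 2 `O=C(N/N=C/c1ccc([N+](=O)[O-])cc1)Nc1ccc(Oc2ccnc3[nH]ccc23)c(F)c1` gives 3030 nM and compound 3 `COc1ccc(/C=N/NC(=O)Nc2ccc(Oc3ccnc4[nH]ccc34)c(F)c2)cc1` gives 1770 nM. Compound 3 stands close to its nearest neighbour, with a 1.7-fold lower number from compound 2 to compound 3 (0.23 log units; within the scatter), and further from the other, with a 2.9-fold lower number from compound 1 to compound 3 (0.47 log units; beyond the scatter).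

Compound 4 `COc1ccc(/C=N/NC(=O)Nc2ccc(Oc3ccnc4[nH]ccc34)cc2)cc1` differs at a single place: hydrogen in place of fluoro on an aromatic carbon. For the measured compounds named here, no measured step touches the fluoro. All three change the aryl group on the carbon with a double bond to nitrogen, and the third of them is a 1.7-fold lower number from compound 1 to compound 2 (0.23 log units; within the scatter). These steps bear on the new change only indirectly, as a guide to how far values move within the series. The expectation therefore starts from compound 3 at 1770 nM, and no step beyond the scatter is expected in this assay, in either direction. The expected change is a 1.1-fold higher number from compound 3 to compound 4 (0.05 log units; within the scatter). Going by these compounds, the range stays wide since the fluoro change is untested. For compound 4 the estimated value is 2000 nM, with an expected range from 800 nM to 5000 nM.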

Compound 4, half-maximal inhibitory concentration: 9740 nM
Beside the measured number, compound 4's estimate is 4.9-fold (0.69 log units) below it, outside the stated range (above it).
By their numbers in this assay, from the lowest: compounds 3, 2, 1 and 4 (each within the scatter of the next, the first and the last beyond it).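

The fluoro position is not neutral in this series: with the 4-methoxyphenyl group held fixed, this assay gives a 5.5-fold higher number from compound 3 to compound 4 (0.74 log units; beyond the scatter). For the compounds shown here, the earlier steps all changed the aryl group, so this is the first reading at the aromatic carbon ortho to a large group and meta to a large group, and it shows that losing one fluorine atom, with hydrogen entering, is enough to pass the scatter. No measurement bears on why the number rises at this position.

Going by these compounds, whether the same step holds with 3-nitrophenyl or 4-nitrophenyl in place of 4-methoxyphenyl remains open, since the fluoro change is seen in one pair only. Also open, on these data alone, is whether chloro, methyl or methoxy at this carbon would behave like fluoro or like hydrogen.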